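A few compounds are considered here, and "the series" means these few. Any claim that something is new, unique, unknown or untested is made for them only; others in the source may bear on it.

Of the compounds shown here, three have so far been measured in a functional assay on L1210 cells (Mus musculus) for cytotoxicity, with a stated time of 48 h; on this read-out higher numbers stand for weaker inhibition and lower numbers for stronger inhibition. Compound 1, `COc1ccc(/C=C2\CCC/C(=C\c3ccc([N+](=O)[O-])cc3)C2=O)cc1`, gives 240000 nM, the highest of the three numbers, which on this read-out makes it the weakest inhibitor of the set. Compound 2, `O=C1CCCC/C1=C\c1ccccc1[N+](=O)[O-]`, gives 23800 nM in this assay, and compound 3, `O=C1CCCC/C1=C\c1ccc([N+](=O)[O-])cc1`, gives 46500 nM in this assay. Both of these numbers lie beyond the usual scatter below that of compound 1, yet neither compound 2 nor compound 3 differs from compound 1 in a single place, so none of these gaps can be tied to one group alone.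

Compound 4, `O=C1/C(=C/c2ccc(Cl)cc2)CCC/C1=C\c1ccc([N+](=O)[O-])cc1`, has not yet been measured. It differs from compound 1 in one place: chloro in place of methoxy on an aromatic carbon. Among the measured compounds shown here, no measured pair shows this exchange, so there is no step of this kind to lean on. The expectation is a modest move toward stronger inhibition, and the step of a 2.4-fold lower number from compound 1 to compound 4 (0.38 log units; beyond the scatter) is therefore estimated to be small, well short of the gaps already seen among the measured compounds. For compound 4 in this assay the estimate is 100000 nM, with a likely range from 30000 nM to 400000 nM.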

Compound 4, half-maximal inhibitory concentration: 9410 nM
The estimate for compound 4 lay 11-fold (1.03 log units) above the measured number; the whole stated range lies above it.
By their numbers in this assay, from the lowest: compound 4; then compounds 2 and 3 (each within the scatter of the next); then compound 1.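

Swapping 4-methoxyphenyl for 4-chlorophenyl, with the rest of the molecule unchanged, gives a 26-fold lower number from compound 1 to compound 4 (1.41 log units; beyond the scatter) in this assay, so the group on this aromatic carbon, para to a large group, has a strong influence on the read-out. Among the compounds shown here, this is the first effect in the set that can be tied to a single exchange of groups, as the earlier compounds offered no pair differing in only one place. Nothing available here explains why the number moves so far.

This single exchange leaves open whether the stronger inhibition comes from the arrival of chloro, the departure of methoxy, or both, and where other groups at this position, such as fluoro, methyl or an amine, would fall. It also leaves open whether the same exchange would have a similar effect in a compound with a different group in place of the nitro group on the other aromatic ring.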